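The source may hold more compounds than are shown below. What is called first, only, known or untested is meant among the compounds shown, and "the series" means these compounds.

The measured compounds:

Compound 1, `COc1cc2ncnc(NNC(=S)NC(=O)c3ccc(Cl)cc3)c2cc1OC`, gives 4590 nM in a functional assay on KB cells (Homo sapiens) for cytotoxicity, read by MTT assay, with a stated time of 72 h; on this read-out lower numbers stand for stronger inhibition and higher numbers for weaker inhibition.
Compound 2, `O=C(NC(=S)NNc1ncnc2ccccc12)c1ccc(Cl)cc1`, gives 3940 nM in this assay.
Compound 3, `COc1cc2ncnc(NNC(=S)NC(=O)c3ccc(C(F)(F)F)cc3)c2cc1OC`, gives 8840 nM in this assay.

All three share a thiosemicarbazide-type linker joining a quinazoline-derived core to a benzoyl group, and they differ in the substituent on that benzoyl ring or in the core. From compound 1 to compound 3 the change is trifluoromethyl in place of chloro on an aromatic carbon. The number moved by a 1.9-fold higher number from compound 1 to compound 3 (0.28 log units; within the scatter), so on this evidence the exchange barely registers on cytotoxicity against these cells. Compound 2 carries a different core from compound 1, and the difference between the two cores is not broken down here; their values, in any case, sit close together.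

Compound 4, `O=C(NC(=S)NNc1ncnc2ccccc12)c1ccc(C(F)(F)F)cc1`, has not yet been measured. Relative to compound 2 it carries trifluoromethyl in place of chloro on an aromatic carbon. This is the same change that separates compound 1 from compound 3, placed on the same kind of position, here on the core of compound 2. The step from compound 1 to compound 3 was modest, and there is no reason in these data to expect a very different outcome when the same change is made on the other core, so the value for compound 4 is estimated to lie around 7500 nM, most likely between 3500 nM and 16000 nM, which would mean an expected step of a 1.9-fold higher number from compound 2 to compound 4 (0.28 log units; within the scatter) from compound 2, resting on the measured step of a 1.9-fold higher number from compound 1 to compound 3 (0.28 log units; within the scatter).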

Compound 4, half-maximal inhibitory concentration: 7920 nM
Compound 4: middle estimate off by 1.1-fold (0.02 log units), on the low side, within the range that was stated.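

In this assay, putting trifluoromethyl in place of chloro on an aromatic carbon of compound 2 gives a 2.0-fold higher number from compound 2 to compound 4 (0.30 log units; within the scatter), so on this core, as on the core of compound 1, the exchange stays inside the normal spread of repeated measurements. Set side by side, the two steps agree: the same change on two cores in this assay, a 1.9-fold higher number (0.28 log units; within the scatter) from compound 1 to compound 3 and a 2.0-fold higher number (0.30 log units; within the scatter) from compound 2 to compound 4, 1.0-fold (0.02 log units) apart, within the scatter of two such steps

For these two cores, then, the step measured on one was a fair guide to the step on the other, and the exchange reads the same on both; this does not show that it would carry over to any further core, and since each step lies within the scatter, it also does not show that the exchange truly alters cytotoxicity at all.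

The compounds shown leave open whether another group at this same place on the ring, such as an amine, a carboxylic acid or a longer chain, would give a step beyond the scatter, and whether such a larger step would also carry from one core to the other. From the compounds shown here alone, whether the two cores would match as closely on other cell types also remains open, since all of these values come from this assay.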